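This account rests on a few compounds, and the source may have more. Where it says the series, first, only, none or still open, it means among the compounds named here.

Measured compounds, all in a functional assay on HeLa cells (Homo sapiens) for inhibition, read by CCK-8 assay, with a stated time of 48 h; a higher number here means a weaker inhibitor, a lower number a stronger inhibitor:
- compound 1 `COc1ccc(C2=NN(C3=NC(c4ccccc4)CS3)C(c3cccc4ccccc34)C2)cc1`: 3310 nM
- compound 2 `Cc1ccc(C2=NN(C3=NC(=O)CS3)C(c3ccc4ccccc4c3)C2)cc1`: 1760 nM
- compound 3 `COc1ccc(C2=NN(C3=NC(c4ccccc4)CS3)C(c3ccc4ccccc4c3)C2)cc1`: 1860 nM

All three numbers sit within the scatter of one another, so no ranking among them can be read. Compound 1 has compound 3 as its nearest neighbour, a 1.8-fold lower number from compound 1 to compound 3 (0.25 log units; within the scatter), a change of naphthalen-2-yl for naphthalen-1-yl on a saturated ring carbon. Compound 2 is the furthest from compound 1, and the two values of compound 1 and compound 2 likewise differ by less than the scatter.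

The unmeasured compound 4 `Cc1ccc(C2=NN(C3=NC(c4ccccc4)CS3)C(c3cccc4ccccc34)C2)cc1C` differs from compound 1 by 3,4-dimethylphenyl in place of 4-methoxyphenyl on a carbon with a double bond to nitrogen. Going by the values given here, no measured step touches this position or this kind of aryl exchange; the single step in hand, from compound 1 to compound 3, concerns a different ring carbon and was itself within the scatter. Nothing in the series therefore points to a shift in this assay in either direction, and the expectation is a step from compound 1 to compound 4 of no more than the scatter, a 1.1-fold lower number from compound 1 to compound 4 (0.04 log units; within the scatter). Compound 4 is estimated at 3000 nM, with a range from 1200 nM to 8000 nM.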

Compound 4, half-maximal inhibitory concentration: 1720 nM
Compound 4: the middle estimate sits 1.7-fold (0.24 log units) above what was measured, and the stated range covers the measured number.
By their numbers in this assay, from the lowest: compounds 4, 2, 3 and 1 (each within the scatter of the next).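

In this assay, going by these compounds alone, the exchange of 4-methoxyphenyl for 3,4-dimethylphenyl gives a 1.9-fold lower number from compound 1 to compound 4 (0.28 log units; within the scatter) and is the first reading at the carbon with a double bond to nitrogen, a position that no earlier pair touched. The exchange removes the oxygen and the one hydrogen-bond acceptor of this aryl group while the count of 8 heavy atoms stays the same, and the step still lies within the scatter, so this one change shows no readable effect on the number at this position. No measurement of any property bears on this step.

The pair leaves open whether any group on this carbon can move the number beyond the scatter, and how a carboxylic acid or a dimethylamino group on the phenyl ring would read here. Also open, going by these compounds, is whether the same exchange reads alike with the naphthalen-2-yl group of compound 3 in place of the naphthalen-1-yl group of compound 1.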